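The source may hold more compounds than are shown below. What is called first, only, known or untested is meant among the compounds shown, and "the series" means these compounds.

Of the compounds shown here, two with a shared core have been tested in an ADME assay on Huh-7 cells (Homo sapiens) for cytotoxicity, with a stated time of 72 h; a higher number here means that more compound is tolerated, a lower number that less compound is tolerated. Compound 1 `CC(C)CCn1nc(-c2cccs2)c(O)c(C2=NS(=O)(=O)c3cc(N(C)S(C)(=O)=O)ccc3N2)c1=O` gives > 33000 nM there, which is a limit of the assay and not a number. Compound 2 `CCC(C)CCn1nc(-c2cccs2)c(O)c(C2=NS(=O)(=O)c3cc(NS(C)(=O)=O)ccc3N2)c1=O` gives > 1000 nM, which is likewise a limit. Compound 2 therefore stands with no numerical value, and the two limits cannot be ranked against each other.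

Compound 3 `COC(C)(C)CCn1nc(-c2cccs2)c(O)c(C2=NS(=O)(=O)c3cc(NS(C)(=O)=O)ccc3N2)c1=O` keeps the core of compound 2 and differs only in its chain, with 1-methoxy-1-methylethyl in place of sec-butyl on a saturated chain carbon, two bonds along the chain from an aromatic nitrogen. Within the data shown here, no measured pair shows what such a change does in this assay, so any forecast is tentative. An estimated step that the limit leaves unreadable from compound 2 to compound 3 is expected, in the direction of more compound being tolerated. That expectation leans on compound 1, the closest relative with a higher limit, at > 33000 nM. For compound 3 the half-maximal cytotoxic concentration is estimated at 20000 nM, with an expected range of 5000 nM to 50000 nM, and it may well be reported only as a limit.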

Compound 3, half-maximal cytotoxic concentration: > 33000 nM
Compound 3 was reported as a limit (the forecaster's own chance of this, stated with the estimate: 85%); middle value at least 1.6-fold (0.21 log units) from the limit.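

In this assay compound 3 gives > 33000 nM, which is a limit and not a number. Among these compounds, compound 2 gives > 1000 nM, also a limit, so no step between compound 2 and compound 3 can be read. The compounds shown leave open what half-maximal cytotoxic concentration any of them has, and what 1-methoxy-1-methylethyl in place of sec-butyl does to it.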